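A few compounds are considered here, and "the series" means these few. Any claim that something is new, unique, unknown or untested is made for them only; others in the source may bear on it.

Three compounds have been measured in an ADME assay (liver) for metabolic stability, with Liver microsome (Rattus norvegicus) as the target, using microsomes; a lower number here means slower removal, a higher number faster removal of the compound:

Compound 1, `c1ccc(CNc2nnc(-c3ccc4cnccc4c3)o2)cc1`, gives 166 mL.min-1.g-1.
Compound 2, `Fc1cc2cc(-c3nnc(NCc4ccccc4)o3)ccc2cn1`, gives 56 mL.min-1.g-1.
Compound 3, `Fc1ncccc1[C@H](Nc1nnc(-c2c[nH]c3ncccc23)o1)C1CC1`, gives 80 mL.min-1.g-1.

Compound 2 differs from compound 1 in one place only: fluoro in place of hydrogen on an aromatic carbon. This single change produced a 3.0-fold lower number from compound 1 to compound 2 (0.47 log units; beyond the scatter), so the fluorinated compound is removed more slowly in this assay.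

Compound 3 is built on a different core; the difference between the two cores is not broken down here. Its number sits close to that of compound 2, and the two cannot be told apart within the usual scatter. Against compound 1 the gap is wider, with compound 1 showing the higher number.

Compound 4, `Fc1cnc2[nH]cc(-c3nnc(N[C@@H](c4cccnc4F)C4CC4)o3)c2c1`, has not yet been measured. It differs from compound 3 by fluoro in place of hydrogen on an aromatic carbon. For the measured compounds named here, this is the same kind of change as the one from compound 1 to compound 2, but not the same: there the fluoro sat next to the ring nitrogen, here it sits two atoms from the ring nitrogen, and the surrounding core is different as well.

The expectation for compound 4 rests on the drop seen as a 3.0-fold lower number from compound 1 to compound 2 (0.47 log units; beyond the scatter), tempered by the different position and core. A somewhat smaller step is estimated, a 2.0-fold lower number from compound 3 to compound 4 (0.30 log units; within the scatter). Compound 4 is therefore estimated at 40 mL.min-1.g-1, most likely between 20 mL.min-1.g-1 and 80 mL.min-1.g-1.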

Compound 4, intrinsic clearance in microsomes: 20 mL.min-1.g-1
For compound 4 the middle estimate is 2.0-fold (0.30 log units) above the measured one; the measured number falls inside the stated range.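

In this assay fluoro in place of hydrogen on an aromatic carbon gave a 4.0-fold lower number from compound 3 to compound 4 (0.60 log units; beyond the scatter) and so, for the second time in these compounds, this single swap went with slower removal. The size of the drop carried over from one core to the other as far as these two pairs can tell, even though the fluoro sits at a different place on a different core: the same change on two cores in this assay, a 3.0-fold lower number (0.47 log units; beyond the scatter) from compound 1 to compound 2 and a 4.0-fold lower number (0.60 log units; beyond the scatter) from compound 3 to compound 4, 1.3-fold (0.13 log units) apart, within the scatter of two such steps

For the compounds shown here, this shows only that the change worked similarly on these two pairs; it does not show that it would do so on further cores or at other places on the ring, and it gives no reason for the drop, as the number records how fast a compound is removed and not what happens to it.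

Still open, as far as these compounds go, is whether another small group in the same place, such as chloro, methyl or methoxy, would lower the number as fluoro does, or whether the effect belongs to fluoro alone. Going by these compounds alone, only one kind of measurement appears here, so it also remains unknown how this swap would affect anything other than removal in this test.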